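Replacing isopropyl with a protected aminobutyl chain on compound 1

The source may report more compounds than this note shows. Statements on the series, on what has been measured and on what is new or still open speak of the compounds shown alone.

Compound 1, `CC(C)[C@H](NC(=O)CN(c1ncnc2c1ncn2C1CCCCO1)C1CC1)C(=O)OCc1ccccc1`: 34.9%
Compound 2, `NC(=O)CC[C@H](NC(=O)CN(c1nc(Cl)nc2[nH]cnc12)C1CC1)C(=O)OCc1ccccc1`: 33.1%
Compound 3, `CC(C)[C@H](NC(=O)CN(c1nc(Cl)nc2[nH]cnc12)C1CC1)C(=O)O`: 38.8%

All three were tested in a functional assay on the whole organism (Tail, strain ICR) with Mus musculus as the target, in the tail flick test, with a stated time of 60 min, at a dose of 25 umol/kg by the oral route; a higher number here means a stronger effect of the compound at the dose given, a lower number a weaker effect. Compound 1 gives 34.9% in this assay, and its gaps to compound 2 and to compound 3 both lie within the usual scatter, so the three numbers cannot be told apart. Compound 4, `CC(C)(C)OC(=O)NCCCC[C@H](NC(=O)CN(c1ncnc2c1ncn2C1CCCCO1)C1CC1)C(=O)OCc1ccccc1`, has not yet been measured. It differs from compound 1 in one place: 4-((tert-butoxycarbonyl)amino)butyl in place of isopropyl on a saturated chain carbon bound to an amide-type nitrogen and a carbonyl carbon. Among the compounds with values here, no pair of measured compounds shows such a change, so there is no step to lean on. The expectation for the step from compound 1 to compound 4, a number 2.9 percentage points lower from compound 1 to compound 4 (within the scatter), is a change of no clear direction and not beyond the scatter. Compound 4 is estimated at 32%, with a range from 18% to 46%.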

Compound 4, a percentage reported as activity, at one dose (the size of the read-out at that dose, not a potency): 32.7%
Estimate against measurement, compound 4: 0.7 percentage points below; low and high end bracket the measured number.
By their numbers in this assay, from the lowest: compounds 4, 2, 1 and 3 (each within the scatter of the next).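

On the saturated chain carbon bound to an amide-type nitrogen and a carbonyl carbon, the far larger 4-((tert-butoxycarbonyl)amino)butyl chain is tolerated in place of isopropyl: this assay shows a number 2.2 percentage points lower from compound 1 to compound 4 (within the scatter) for this swap. So at this one dose, the read-out does not separate the long chain from the small branched group. No supporting measurement bears on this result.

Going by these compounds, a 4-aminobutyl chain with a free amine, or a chain ending in a carboxylic acid, remains open. So does whether the same tolerance holds at other doses.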